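Chain length of the hydroxamic acid on the shared core

A few compounds are considered here, and "the series" means these few. Any claim that something is new, unique, unknown or untested is made for them only; others in the source may bear on it.

Measured so far:
compound 1, `Nc1ncnc2c1c(-c1cnc3[nH]ccc3c1)nn2CCCC(=O)NO` — > 150000 nM
compound 2, `Nc1ncnc2c1c(-c1cnc3[nH]ccc3c1)nn2CCCCC(=O)NO` — > 150000 nM

In a functional assay on CNE-2 cells (Homo sapiens) for inhibition, read by MTT assay, with a stated time of 72 h (a lower number here means a stronger inhibitor, a higher number a weaker inhibitor), compound 1 gives only a limit of the assay, > 150000 nM. Compound 2 likewise gives only a limit, > 150000 nM. Both values sit at the limit of > 150000 nM in this assay, at which 2 of the 2 values shown sit, so the step that the two limits leave unreadable from compound 1 to compound 2 has no readable size. Compound 3, `Nc1ncnc2c1c(-c1cnc3[nH]ccc3c1)nn2CCC(=O)NO`, differs from compound 2 by hydroxycarbamoyl in place of 2-(hydroxycarbamoyl)ethyl on a saturated chain carbon, two bonds along the chain from an aromatic nitrogen. Among the compounds with values here, no measured step bears a readable size on this change, so the expectation rests on where compound 2 stands. Compound 3 is expected at 150000 nM, in the range 50000 nM to 400000 nM, most likely again as a limit. The step of a number no higher from compound 2 to compound 3 (the limit leaves the size open) is expected to show no change beyond the scatter.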

Compound 3, half-maximal inhibitory concentration: > 150000 nM
Compound 3: no number, only a limit; the forecaster's own chance of this, stated with the estimate: 80%; the middle value sits exactly at the limit.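

No step among compound 1, compound 2 and compound 3 can be read, as all three give only limits in this assay: the limit of > 150000 nM in this assay, at which 3 of the 3 values shown sit.

Whether chain length on the shared core affects inhibition in this assay remains open, as the compounds shown give no number to compare.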